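A Methoxy in Place of the Methylcyclopropyl

The source may report more compounds than this note shows. Statements on the series, on what has been measured and on what is new or still open speak of the compounds shown alone.

Compound 2 `C[C@H]1C[C@@H]1C(=O)N1CC2CNCC2C1` gives 26% in an assay on CHO cells for agonist activity at Neuronal acetylcholine receptor; alpha3/beta4 (Homo sapiens), read by FLIPR and calcium flux (a higher number here means a larger maximal response, a lower number a smaller maximal response), the lowest of the three numbers shown. Its nearest neighbour is compound 3 `CC(=O)N1CC2CNCC2C1`, which in this assay gives 36%; the step of a number 10 percentage points higher from compound 2 to compound 3 (within the scatter) lies within the scatter. Compound 1 `C[C@@H]1C[C@@H]1C(=O)N1CC2CNCC2C1` gives 180% in this assay, and the step of a number 154 percentage points lower from compound 1 to compound 2 (beyond the scatter) is large; the one observation that bears on that step is the fact that one of compounds 1 and 2 is drawn with a defined configuration and the other without, at the place where they differ. The step of a number 144 percentage points lower from compound 1 to compound 3 (beyond the scatter) is large as well.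

Compound 4 `COC(=O)N1CC2CNCC2C1` differs from compound 2 by methoxy in place of 2-methylcyclopropyl on a carbonyl carbon. The measured step that bears on this change is the earlier exchange of the same 2-methylcyclopropyl for methyl, a number 10 percentage points higher from compound 2 to compound 3 (within the scatter), which stayed within the scatter. A methyl or a methoxy on the carbonyl carbon is therefore expected to leave the response close to where compound 2 and compound 3 sit, with no step beyond the scatter. Compound 4 is estimated at 35%, within 10% to 80%. The step of a number 9 percentage points higher from compound 2 to compound 4 (within the scatter) is expected to stay within the scatter.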

Compound 4, largest response reached (Emax), in percent of the reference or control that the assay uses: 85%
Compound 4: middle estimate off by 50 percentage points, on the low side; the whole stated range lies below it.
By their numbers in this assay, from the lowest: compounds 2 and 3 (each within the scatter of the next); then compound 4; then compound 1.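

In this assay methoxy and methyl on a carbonyl carbon do not give the same response, with a number 49 percentage points higher from compound 3 to compound 4 (beyond the scatter) when one replaces the other. The outcome of removing the 2-methylcyclopropyl thus depends on the group that enters: a number 59 percentage points higher from compound 2 to compound 4 (beyond the scatter) with methoxy, whereas the exchange for methyl stayed within the scatter. The methoxy compound still does not match the 2-methylcyclopropyl compound with the other drawn configuration, with a number 95 percentage points lower from compound 1 to compound 4 (beyond the scatter) in this comparison.

The compounds shown offer no measurement that accounts for the difference between methoxy and methyl. From the compounds shown here alone, it also remains open whether an ethoxy group, or a dimethylamino group on the same carbonyl carbon, would give a response nearer to that of the methoxy compound or of the methyl compound.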